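Aryl swap at the saturated ring carbon: compound 3

This account rests on a few compounds, and the source may have more. Where it says the series, first, only, none or still open, it means among the compounds named here.

Compound 2 `COc1cccc(C2C=C(c3cc(OC)c(OC)c(OC)c3)NC(=S)N2)c1` gives 59500 nM in a functional assay on B16 cells (Mus musculus) for cytotoxicity, read by MTT assay, with a stated time of 72 h (a higher number here means a weaker inhibitor, a lower number a stronger inhibitor), and stands at the top of the two numbers shown, though within the scatter of compound 1 `COc1ccc(OC)c(C2C=C(c3cc(OC)c(OC)c(OC)c3)NC(=S)N2)c1`, which gives 36000 nM; the step of a 1.7-fold higher number from compound 1 to compound 2 (0.22 log units; within the scatter) does not separate them. Compound 3 `COc1cc(C2=CC(c3ccc(Cl)cc3)NC(=S)N2)cc(OC)c1OC` differs from compound 2 by 4-chlorophenyl in place of 3-methoxyphenyl on a saturated ring carbon. For the measured compounds named here, the only measured step, hydrogen in place of methoxy on an aromatic carbon, lay within the scatter, and it is the sole guide here, so no step beyond the scatter is expected for compound 3. Compound 3 is estimated at 50000 nM (range 20000 nM to 130000 nM), an expected step of a 1.2-fold lower number from compound 2 to compound 3 (0.08 log units; within the scatter).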

Compound 3, half-maximal inhibitory concentration: 55500 nM
Beside the measured number, compound 3's estimate is 1.1-fold (0.05 log units) below it; low and high end bracket the measured number.
By their numbers in this assay, from the lowest: compounds 1, 3 and 2 (each within the scatter of the next).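

At the saturated ring carbon, 4-chlorophenyl in place of 3-methoxyphenyl gives a 1.1-fold lower number from compound 2 to compound 3 (0.03 log units; within the scatter) in this assay. The earlier pair varied only a methoxy on the aryl group at this carbon, whereas here the whole aryl group is exchanged, with chlorine entering and the methoxy leaving, and the step still does not leave the scatter. No available evidence bears on the reason for this result.

Open, going by these compounds, is whether an amine or a carboxylic acid on this aryl ring would give a step beyond the scatter. Also open, on these data alone, is whether a longer chain in place of the aryl ring at this carbon would do so.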